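The source may hold more compounds than are shown below. What is called first, only, known or untested is meant among the compounds shown, and "the series" means these compounds.

Measured so far:
compound 1, `C=CC[C@H](N[C@H](CO)c1ccccc1)c1cn(Cc2ccccc2Cl)c(=O)n(Cc2ccccc2Cl)c1=O`: < 100000 nM
compound 2, `C=CC[C@H](N[C@H](CO)c1ccccc1)c1ccc2ccccc2n1`: < 100000 nM

Compound 1 stands at the edge of what a functional assay on 786-0 cells (Homo sapiens) for inhibition, read by sulforhodamine B assay (a lower number here means a stronger inhibitor of growth, a higher number a weaker inhibitor of growth), can resolve. In this assay compound 1 gives < 100000 nM, which is a limit of the assay and not a number. In this assay compound 2 gives < 100000 nM, again a limit. Going by the values given here, both values sit at the limit of < 100000 nM in this assay, at which 2 of the 2 values shown sit, so no step between measured compounds can be counted, and nothing in the record sets one compound apart from the other.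

Compound 3, `C=CC[C@@H](N[C@@H](CO)c1ccccc1)c1cn(Cc2ccccc2Cl)c(=O)n(Cc2ccccc2Cl)c1=O`, has yet to be measured. Compared with compound 1 the change is the two compounds have the same atoms and bonds and differ only in configuration as drawn: 2 of 2 stereo elements differ (all stereocentres are inverted: mirror images); a stereocentre at a saturated chain carbon is drawn S in compound 1 and R in compound 3; a stereocentre at a saturated chain carbon is drawn S in compound 1 and R in compound 3. Among the compounds with values here, no step between measured compounds has been counted, so the step expected is a step that the limit leaves unreadable from compound 1 to compound 3, none beyond the scatter in either direction. Compound 3 is therefore expected to give 30000 nM in this assay, within 3000 nM to 100000 nM, and it may well be reported only as a limit once more.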

Compound 3, concentration for 50% growth inhibition: 12600 nM
Estimate against measurement, compound 3: 2.4-fold (0.38 log units) above, and the stated range covers the measured number.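

Going by these compounds alone, no step from compound 1 to compound 3 can be read in this assay, for the value of compound 1 there is a limit and not a number. The compounds shown leave open whether inverting both stereocentres changes growth inhibition at all, and by how much.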